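Adding a Second Methoxy Group to Compound 1

This account rests on a few compounds, and the source may have more. Where it says the series, first, only, none or still open, it means among the compounds named here.

Measured compounds:
Compound 1, `COc1ccc(-c2cc(/C=C/C(=O)c3ccc(N)cc3)[nH]n2)cc1`: in a functional assay on MDA-MB-468 cells (Homo sapiens) for inhibition, read by sulforhodamine B assay, with a stated time of 48 h (on this read-out higher numbers stand for weaker inhibition of growth and lower numbers for stronger inhibition of growth), compound 1 gives 2090 nM.
Compound 2, `COc1cc(-c2cc(/C=C/C(=O)c3ccc(F)c(F)c3)[nH]n2)cc(OC)c1OC`: in this assay compound 2 gives 9470 nM.

Compound 1 has the lower of the two numbers, and compound 2 stands well apart from it, beyond the usual scatter. Compound 2 differs from compound 1 in more than one place, so the two values together cannot be traced to any single change.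

Compound 3, `COc1ccc(-c2cc(/C=C/C(=O)c3ccc(N)cc3)[nH]n2)cc1OC`, has not been measured. It differs from compound 1 by methoxy in place of hydrogen on an aromatic carbon. Going by the values given here, no measured pair shows this change on its own, so the outcome is open. Its size in this assay is expected to be small, within or close to the scatter, with no clear direction. Compound 3 is therefore expected to give about 2500 nM, roughly between 900 nM and 7000 nM, which means an expected step of a 1.2-fold higher number from compound 1 to compound 3 (0.08 log units; within the scatter).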

Compound 3, concentration for total growth inhibition: 3480 nM
Compound 3: the middle estimate sits 1.4-fold (0.14 log units) below what was measured, within the range that was stated.
By their numbers in this assay, from the lowest: compounds 1 and 3 (each within the scatter of the next); then compound 2.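

Methoxy in place of hydrogen on an aromatic carbon, ortho to a methoxy group and meta to a large group, gives a 1.7-fold higher number from compound 1 to compound 3 (0.22 log units; within the scatter) in this assay and is the first single change that can be read here. Because that step lies within the usual scatter, compound 1 and compound 3 cannot be told apart, so this position accepts the added methoxy without a difference this read-out can resolve. Nothing available explains this result.

As far as these compounds go, whether a longer ethoxy chain or a hydroxyl group at the same place would also stay within the scatter of compound 1 remains open. Compound 2 differs from compound 3 in more than one place, so the gap between their values cannot be assigned to any single group.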